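The compounds below may be only part of what the source reports. "The series", "measured", "known", "first", "only" and "open" are said of these compounds alone.

Notes on the series. In a physicochemical assay for solubility, measured as kinetic solubility, with a stated time of 1 h, at pH 7.4 (on this read-out higher numbers stand for higher solubility and lower numbers for lower solubility), compound 3 (`O=C(NC1=NN(c2ccc(Cl)c(Cl)c2)CC1)c1cccnc1`) reads 4000 nM. Compound 1 (`O=C(Nc1nc(-c2ccc(Cl)c(Cl)c2)cs1)c1c(F)cccc1F`) reads 5000 nM, within the scatter of compound 3. Compound 2 (`N#CCC(=O)Nc1nc(-c2ccc(Cl)c(Cl)c2)cs1`) reads 57000 nM, the highest of the three numbers and beyond the scatter of the other two.

Compound 4 (`O=C(NC1=NN(c2ccc(Cl)c(Cl)c2)CC1)c1ccncc1F`) is still to be measured in this assay. The structural change is 3-fluoropyridin-4-yl in place of pyridin-3-yl on a carbonyl carbon, with the rest of compound 3 kept.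

Among the measured compounds shown here, only one measured step bears on this, and only loosely. It is an 11-fold higher number from compound 1 to compound 2 (1.06 log units; beyond the scatter), a large step that also falls on a carbonyl carbon. In that step cyanomethyl replaces 2,6-difluorophenyl, so an aromatic ring is lost, and the core of compound 1 is not the core of compound 3. In the change to compound 4, one six-membered aromatic ring stands in place of another. For the measured compounds named here, no measured pair isolates such a swap, so the large step is not carried over, and the expectation stays anchored on compound 3 at 4000 nM.

The estimated step is a 1.1-fold lower number from compound 3 to compound 4 (0.06 log units; within the scatter), not expected to lie beyond the scatter. Compound 4 is estimated at 3500 nM, with an expected range from 1500 nM to 8000 nM.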

Compound 4, solubility: 36000 nM
The estimate for compound 4 lay 10-fold (1.01 log units) below the measured number; the measured number lies above the stated range.
By their numbers in this assay, from the lowest: compounds 3 and 1 (each within the scatter of the next); then compounds 4 and 2 (each within the scatter of the next).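

Working notes on the series. In this assay, replacing pyridin-3-yl with 3-fluoropyridin-4-yl on a carbonyl carbon whose other neighbour is an amide-type nitrogen gives a 9.0-fold higher number from compound 3 to compound 4 (0.95 log units; beyond the scatter), so on this core the read-out at this place can move well beyond the scatter without any aromatic ring being lost. The earlier step, an 11-fold higher number from compound 1 to compound 2 (1.06 log units; beyond the scatter), replaced an aromatic ring with cyanomethyl on a different core, whereas here a six-membered aromatic ring with one hetero atom stands on both sides and the counts of hydrogen-bond donors and acceptors and the net charge do not differ. No measurement bearing on the groups involved is available to account for the step.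

The change combines the added fluorine with the move from a pyridin-3-yl to a pyridin-4-yl attachment, and the compounds shown do not separate the two; a plain pyridin-4-yl or a 3-fluoropyridin-3-yl-free comparison such as 3-chloropyridin-4-yl on the same core would be needed. From the compounds shown here alone, whether 3-fluoropyridin-4-yl would give a similar step on the core of compound 1 also stays open.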